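Removing a methoxy from the pyrazole-side trimethoxyphenyl ring

The source may report more compounds than this note shows. Statements on the series, on what has been measured and on what is new or still open speak of the compounds shown alone.

Compound 1 `COc1ccc(-c2cc(/C=C/C(=O)c3ccc(N)cc3)[nH]n2)cc1` and compound 2 `COc1ccc(-c2cc(/C=C/C(=O)c3ccc(N)cc3)[nH]n2)cc1OC` share a core, and in a functional assay on TK-10 cells (Homo sapiens) for inhibition, read by sulforhodamine B assay, with a stated time of 48 h (a lower number here means that less compound is tolerated, a higher number that more compound is tolerated), compound 1 gives 39800 nM while compound 2 gives 48700 nM. The step of a 1.2-fold lower number from compound 2 to compound 1 (0.09 log units; within the scatter) comes from hydrogen in place of methoxy on an aromatic carbon. Compound 3 `COc1cc(C(=O)/C=C/c2cc(-c3cc(OC)c(OC)c(OC)c3)n[nH]2)cc(OC)c1OC` gives 5340 nM in this assay; the difference between the cores of compound 3 and compound 2 is not broken down here. Compound 4 `COc1ccc(-c2cc(/C=C/C(=O)c3cc(OC)c(OC)c(OC)c3)[nH]n2)cc1OC` is not yet measured. It arises from compound 3 by hydrogen in place of methoxy on an aromatic carbon, the same kind of change as from compound 2 to compound 1, though here the place is also meta to a methoxy group. Because the earlier step of a 1.2-fold lower number from compound 2 to compound 1 (0.09 log units; within the scatter) stayed within the scatter, the step of a 1.1-fold lower number from compound 3 to compound 4 (0.03 log units; within the scatter) is expected to be small as well. Compound 4 is therefore estimated at 5000 nM in this assay, with a likely range from 2500 nM to 12000 nM.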

Compound 4, concentration lethal to 50% of the cells: 36900 nM
Compound 4: the middle estimate sits 7.4-fold (0.87 log units) below what was measured; the measured number lies above the stated range.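

In this assay, hydrogen in place of methoxy on an aromatic carbon gives a 6.9-fold higher number from compound 3 to compound 4 (0.84 log units; beyond the scatter). Within the data shown here, the same change does not carry over at a fixed size between these two cores: the same change on two cores in this assay, a 1.2-fold lower number (0.09 log units; within the scatter) from compound 2 to compound 1 and a 6.9-fold higher number (0.84 log units; beyond the scatter) from compound 3 to compound 4, 8.5-fold (0.93 log units) apart, beyond the scatter of two such steps With only two pairs, this shows that the size of the step differed with the core here, but it does not show which difference between the cores accounts for that, nor what the change would do on any further core.

The compounds shown leave open what a hydroxyl group, a fluorine atom or an ethoxy group would give in that place on either core. They also leave open whether removing a second methoxy from compound 4 would shift the number further.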